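This account rests on a few compounds, and the source may have more. Where it says the series, first, only, none or still open, it means among the compounds named here.

Compound 1 `CCc1nc2cc(OC3CCN(C(C)=N)CC3)ccc2n1Cc1ccc2ccc(C(=N)N)cc2c1` in an assay on isolated protein for inhibition of serine protease 1 (Bos taurus) (on this read-out lower numbers stand for stronger inhibition and higher numbers for weaker inhibition), gives 17 nM; compound 2 `CC(=N)N1CCC(Oc2ccc3c(c2)nc(CCC(=O)O)n3Cc2ccc3ccc(C(=N)N)cc3c2)CC1` in this assay gives 14 nM.

On these two numbers compound 2 gives the lower one, but the step of a 1.2-fold lower number from compound 1 to compound 2 (0.08 log units; within the scatter), a carboxy added on the chain, lies within the scatter, so the two compounds are not separated. Compound 3 `CC(=N)N1CCC(Oc2ccc3c(c2)nc(C(C)C)n3Cc2ccc3ccc(C(=N)N)cc3c2)CC1` differs from compound 2 in the same region: isopropyl in place of 2-carboxyethyl on an aromatic carbon. Among the compounds with values here, only the step from compound 1 to compound 2 bears on this change, and it was flat, so no step beyond the scatter is expected in this assay. For compound 3 the expected value is 16 nM, with a range of 6 nM to 45 nM, a step of a 1.1-fold higher number from compound 2 to compound 3 (0.06 log units; within the scatter).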

Compound 3, inhibition constant: 16 nM
Estimate against measurement, compound 3: no gap at the digits printed; the measured number falls inside the stated range.
By their numbers in this assay, from the lowest: compounds 2, 3 and 1 (each within the scatter of the next).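

In this assay, isopropyl in place of 2-carboxyethyl on this aromatic carbon, between two ring nitrogen atoms, gives a 1.1-fold higher number from compound 2 to compound 3 (0.06 log units; within the scatter). The methyl added on the chain carbon bound to the ring gives a 1.1-fold lower number from compound 1 to compound 3 (0.03 log units; within the scatter), so all three groups at this position remain unseparated, whether or not the group carries a hydrogen-bond donor or acceptor. Nothing available explains why these numbers stay so close. As far as these compounds go, whether an amine, a phenyl ring or a much longer chain on this carbon would give a step beyond the scatter remains open.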